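A few compounds are considered here, and "the series" means these few. Any claim that something is new, unique, unknown or untested is made for them only; others in the source may bear on it.

In a functional assay on PC-3 cells (Homo sapiens) for inhibition, read by sulforhodamine B assay, with a stated time of 48 h, tested at 50 uM (on this read-out lower numbers stand for less inhibition of growth and higher numbers for more inhibition of growth at the one concentration tested), three compounds have been measured so far. Compound 1 (`COc1ccc([C@@H]2C/C(=N/OCc3cn(-c4ccccc4CO)nn3)c3cc(CC=C(C)C)c(OC)cc3O2)cc1`) gives 100% and stands highest of the three, beyond the scatter from both others. Compound 2 (`C#CCOc1ccc([C@@H]2CC(=O)c3cc(CC=C(C)C)c(OC)cc3O2)cc1`) gives 52% and compound 3 (`COc1cc2c(cc1CC=C(C)C)C(=O)C[C@@H](c1ccc(Oc3ccccc3)cc1)O2`) gives 53% but neither carries the side chain of compound 1.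

Compound 4 (`COc1ccc([C@@H]2C/C(=N/OCc3cn(-c4cccnc4Cl)nn3)c3cc(CC=C(C)C)c(OC)cc3O2)cc1`) has not yet been measured. It differs from compound 1 in one place (2-chloropyridin-3-yl in place of 2-(hydroxymethyl)phenyl on an aromatic nitrogen): 2-chloropyridin-3-yl in place of 2-(hydroxymethyl)phenyl on an aromatic nitrogen of a five-membered aromatic ring with 3 nitrogen.

Among the compounds with values here, the only measured step between compounds differing in one place is a number 1 percentage points higher from compound 2 to compound 3 (within the scatter) and it lies within the scatter. That step exchanges phenyl in place of propargyl on an oxygen on an aromatic ring, elsewhere in the molecule, so it offers only weak guidance. Within the data shown here, no measured step covers the place where compound 4 departs from compound 1. Compound 1 already gives 100% so the number has little room to rise, and any real change is expected to be downward. The expected change is modest, an estimated a number 15 percentage points lower from compound 1 to compound 4 (beyond the scatter) in this assay with wide uncertainty. Compound 4 is estimated at 85% with 55% to 100% as the expected range.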

Compound 4, percent growth inhibition at one concentration: 44%
Compound 4: middle estimate off by 41 percentage points, on the high side; measured number outside the range, below it.
By their numbers in this assay, from the lowest: compounds 4, 2 and 3 (each within the scatter of the next); then compound 1.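

Read in this assay, the group on the aromatic nitrogen of the five-membered ring proves to matter a great deal: replacing 2-(hydroxymethyl)phenyl with 2-chloropyridin-3-yl gives a number 56 percentage points lower from compound 1 to compound 4 (beyond the scatter). Within the data shown here, the only earlier step lay elsewhere in the molecule and stayed within the scatter, so this is the first sign that the number responds strongly to a single exchange, and that the shared side chain does not hold the top number whatever aromatic ring it carries. No measurement at hand bears on why the number falls.

The exchange alters several things at once, since the entering ring holds a nitrogen and a chlorine while the hydroxymethyl group with its hydrogen-bond donor leaves, and the compounds shown do not separate these changes. They also leave open how this assay would read for a phenyl ring carrying an aminomethyl group or a carboxylic acid in place of the hydroxymethyl group, which would show whether the number follows that particular group or tolerates other substituents there.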